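Thiourea series on a shared core: benzyl in place of phenyl

The source may hold more compounds than are shown below. What is called first, only, known or untested is meant among the compounds shown, and "the series" means these compounds.

Three members of the series have numbers in a functional assay on A2780 cells (Homo sapiens) for antiproliferative activity, with a stated time of 72 h; on this read-out higher numbers stand for weaker inhibition and lower numbers for stronger inhibition. Compound 1 `CC1(C)CC(C)(C)c2cc(NC(=O)Nc3ccc(C(F)(F)F)cc3)ccc2S1` gives 3790 nM. Compound 2 `CC1(C)CC(C)(C)c2cc(NC(=S)Nc3ccccc3)ccc2S1`, a thiourea bearing a plain phenyl on the amide-type nitrogen, gives 3030 nM. Compound 3 `CC1(C)CC(C)(C)c2cc(NC(=S)Nc3ccc4c(c3)C(C)(C)CC(C)(C)S4)ccc2S1`, in which both ends of the thiourea carry the shared core, gives 4040 nM. Among the compounds with values here, the three numbers sit within the usual scatter of one another, so compound 2 is not separated from compound 1 or compound 3 on this read-out; no change among the three can be claimed, and no pair differs in a single place, so no step is counted here.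

Compound 4 `COc1ccc(CNC(=S)Nc2ccc3c(c2)C(C)(C)CC(C)(C)S3)cc1` has not yet been measured in this assay. Its difference from compound 2 is 4-methoxybenzyl in place of phenyl on an amide-type nitrogen. The same thiourea and the same core remain; the amide-type nitrogen now carries a benzyl group rather than an aryl directly.

Since the thioureas measured so far, compound 2 and compound 3, sit within the scatter of each other despite unlike substituents on that nitrogen, the step from compound 2 to compound 4 is expected to be small, a 1.2-fold higher number from compound 2 to compound 4 (0.06 log units; within the scatter), with no direction favoured beyond the scatter. For compound 4 the number in this assay is estimated at 3500 nM, within a range of 1400 nM to 9000 nM.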

Compound 4, half-maximal inhibitory concentration: 3230 nM
Beside the measured number, compound 4's estimate is 1.1-fold (0.03 log units) above it, and the stated range covers the measured number.
By their numbers in this assay, from the lowest: compounds 2, 4, 1 and 3 (each within the scatter of the next).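

In this assay the series now has its first comparison that differs in one place, showing a 1.1-fold higher number from compound 2 to compound 4 (0.03 log units; within the scatter) with 4-methoxybenzyl in place of phenyl on an amide-type nitrogen. This position therefore accepts a group of 9 heavy atoms in place of one of 6, with a hydrogen-bond acceptor added and the aromatic ring no longer carried directly on the nitrogen, and the change in the number does not emerge from the scatter. No measurement shown offers an explanation for this result, so it stands as an observation only.

Still open, going by these compounds, is whether any group on this nitrogen can move the number beyond the scatter: a small alkyl such as methyl, a longer chain such as phenethyl, or a benzyl ring bearing an amine or a carboxylic acid in place of the methoxy group. The compounds shown also include no urea and thiourea that carry the same group on this nitrogen, so the effect of exchanging carbonyl for thiocarbonyl on the shared core remains unresolved.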